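Compound 3 to compound 4: chloro replaces trifluoromethoxy

The source may hold more compounds than are shown below. What is called first, only, known or untested is meant among the compounds shown, and "the series" means these compounds.

In an ADME assay on BJ cells (Homo sapiens) for cytotoxicity, with a stated time of 72 h (a lower number here means that less compound is needed, a higher number that more compound is needed for the effect), compound 1 `Cc1cc(NC(=O)Nc2ccc(C(F)(F)F)cc2)c2ccccc2n1` reports only a limit, > 25000 nM. Compound 2 `Cc1cc(NC(=O)Nc2ccc(O)cc2)c2ccccc2n1` also reports only a limit, > 25000 nM. Going by the values given here, compound 3 `Cc1cc(NC(=O)Nc2ccc(OC(F)(F)F)cc2)c2ccccc2n1` gives 25000 nM, the only true number among the three. Compound 3 therefore stands level with the limit of > 25000 nM in this assay, at which 2 of the 3 values shown sit.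

Compound 4 `Cc1cc(NC(=O)Nc2ccc(Cl)cc2)c2ccccc2n1` carries chloro in place of trifluoromethoxy on an aromatic carbon, (chloro in place of trifluoromethoxy on an aromatic carbon). The measured steps that bear on this change are a number no higher from compound 1 to compound 3 (the limit leaves the size open), a number no higher from compound 2 to compound 3 (the limit leaves the size open) and a step that the two limits leave unreadable from compound 1 to compound 2. None of them has a readable size, so none points to a shift in either direction. The estimated change is no change at the digits printed from compound 3 to compound 4 (within the scatter), with nothing expected beyond the scatter. For compound 4 the expected value is 25000 nM, with an estimated range from 13000 nM to 40000 nM.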

Compound 4, half-maximal effective concentration: > 25000 nM
Compound 4: only a limit was reported (the forecaster's own chance of this, stated with the estimate: 65%); the middle value sits exactly at the limit.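

In this assay compound 4 reports only a limit, > 25000 nM. The change gives a number no lower from compound 3 to compound 4 (the limit leaves the size open), and neither this step nor the others from compound 4 can be read in size. What is new is that a single chlorine, with no oxygen or fluorine, on this aromatic carbon also leaves the value at the limit, as trifluoromethyl and hydroxy do: the limit of > 25000 nM in this assay, at which 3 of the 4 values shown sit.

The compounds shown leave open whether an amine or a carboxylic acid at this place would give a true number, and whether any group here brings a readable change in this assay.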